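Replacing the 4-Methoxyphenyl on the Amide Nitrogen with Hydrogen

A few compounds are considered here, and "the series" means these few. Any claim that something is new, unique, unknown or untested is made for them only; others in the source may bear on it.

Compound 1 (`COc1ccc(NC(=O)/C(C#N)=C/c2cc(O)c(O)c([N+](=O)[O-])c2)cc1`) carries a 4-methoxyphenyl group on its amide nitrogen. In a functional assay on Bel-7402 cells (Homo sapiens) for antiproliferative activity, read by MTT assay (a lower number here means a stronger inhibitor, a higher number a weaker inhibitor), compound 1 gives > 100 ug/mL, which is a limit of the measurement rather than a number. The other measured compound, compound 2 (`COc1c(O)ccc(/C=C(\C#N)C(=O)Nc2cccc(Cl)c2)c1[N+](=O)[O-]`), gives 65.3 ug/mL in this assay. Compound 1 therefore stands at the limit of > 100 ug/mL in this assay, at which 1 of the 2 values shown sits, so its true value is known only to lie on the weak side of that boundary. Within the data shown here, no two measured compounds differ in a single place, so no measured step is available to guide the next change.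

The unmeasured compound 3 (`N#C/C(=C\c1cc(O)c(O)c([N+](=O)[O-])c1)C(N)=O`) differs from compound 1 in one place: hydrogen in place of 4-methoxyphenyl on an amide-type nitrogen. With compound 1 known only as a limit, the size of the step can only be guessed; the expected step is a number no higher from compound 1 to compound 3 (the limit leaves the size open), a move that would not clearly reach beyond the usual scatter. For compound 3 in this assay the expected value is 100 ug/mL, within a range from 40 ug/mL to 300 ug/mL, and a reported limit instead of a number is the more likely outcome.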

Compound 3, half-maximal inhibitory concentration: > 100 ug/mL
Compound 3: no number, only a limit; the forecaster's own chance of this, stated with the estimate: 65%; the middle value sits exactly at the limit.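

In this assay compound 3 gives > 100 ug/mL, which is a limit and not a number. Compound 1 is also known only as a limit, so no step can be read between compound 1 and compound 3, and both sit at the same boundary: the limit of > 100 ug/mL in this assay, at which 2 of the 3 values shown sit. The compounds shown leave open whether swapping 4-methoxyphenyl for hydrogen on the amide nitrogen changes the true activity at all.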